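Swapping chloro for hydroxy on a growth inhibitor

The source may report more compounds than this note shows. Statements on the series, on what has been measured and on what is new or still open speak of the compounds shown alone.

Compound 1 `O=C1CC(N2C(=O)CSC2=S)C(=O)N1c1ccc(Cl)cc1`: "nd" (no result reported)
Compound 2 `O=C1CC(N2C(=O)/C(=C/C(Cl)=C/c3ccc([N+](=O)[O-])cc3)SC2=S)C(=O)N1c1ccc(Cl)cc1`: 70300 nM

Among the compounds with values here, in a functional assay on KB 3-1 cells (Homo sapiens) for inhibition, read by MTT assay, with a stated time of 72 h (on this read-out higher numbers stand for weaker inhibition of growth and lower numbers for stronger inhibition of growth), compound 2 gives 70300 nM, the only number available, so it cannot yet be ranked against anything. Compound 3 `O=C1CC(N2C(=O)/C(=C/C(Cl)=C/c3ccc([N+](=O)[O-])cc3)SC2=S)C(=O)N1c1ccc(O)cc1` has hydroxy in place of chloro on an aromatic carbon, para to a large group, turning 4-chlorophenyl into 4-hydroxyphenyl: hydroxy in place of chloro on an aromatic carbon. Within the data shown here, no measured pair shows what this swap does here, so any forecast is uncertain. A modest move toward stronger inhibition of growth is expected, with an estimated 2.3-fold lower number from compound 2 to compound 3 (0.37 log units; beyond the scatter). Compound 3 is estimated at 30000 nM, within a range of 8000 nM to 100000 nM.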

Compound 3, concentration for 50% growth inhibition: 8000 nM
The estimate for compound 3 lay 3.8-fold (0.57 log units) above the measured number; low and high end bracket the measured number.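

In this assay, hydroxy in place of chloro gives an 8.8-fold lower number from compound 2 to compound 3 (0.94 log units; beyond the scatter). This shows that growth inhibition in this series responds to what sits on this aromatic carbon, para to a large group, even when only one heavy atom is exchanged. No measurement shown here explains the step.

On these data alone, whether the hydroxy itself matters or the loss of chloro is enough remains open, as does how an amine, a methoxy or a carboxylic acid would compare at this place. A single pair also cannot show whether this swap would act alike on another core.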